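Phenyl to methylthiophene on the acrylic acid series

The source may hold more compounds than are shown below. What is called first, only, known or untested is meant among the compounds shown, and "the series" means these compounds.

Measured in a functional assay on MCF7 cells (Homo sapiens) for cytotoxicity, read by CellTiter-Glo, with a stated time of 5 days; on this read-out lower numbers stand for stronger inhibition and higher numbers for weaker inhibition:
compound 1 `CC/C(=C(/c1ccc(/C=C/C(=O)O)cc1)c1ccc2[nH]c(=O)sc2c1)c1ccccc1`: 158 nM
compound 2 `CC/C(=C(/c1ccc(/C=C/C(=O)O)cc1)c1ccc2[nH]ncc2c1)c1ccccc1`: 6 nM
compound 3 `CC/C(=C(\c1ccc2[nH]ncc2c1)c1ccc(/C=C/C(=O)O)cc1OC)c1ccccc1`: 12 nM

Compound 2 gives the lowest number of the three; compound 3 lies within the scatter of it, and compound 1 stands apart, a 26-fold lower number from compound 1 to compound 2 (1.42 log units; beyond the scatter). The change from compound 2 to compound 3 is small, a 2.0-fold higher number from compound 2 to compound 3 (0.30 log units; within the scatter).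

Compound 4 `CC/C(=C(/c1ccc(/C=C/C(=O)O)cc1)c1ccc2[nH]ncc2c1)c1cscc1C` differs from compound 2 as follows: 4-methylthiophen-3-yl in place of phenyl on a double-bonded chain carbon bound to a double-bonded chain carbon and a saturated chain carbon. Among the compounds with values here, no measured step touches this place. Within the data shown here, the one large step, from compound 1 to compound 2, swapped an aromatic group elsewhere; the other step, methoxy for hydrogen, stayed within the scatter. A step not far beyond the scatter is therefore expected, direction uncertain: a 2.0-fold higher number from compound 2 to compound 4 (0.30 log units; within the scatter). Compound 4 is estimated at 12 nM in this assay, with a range of 4 nM to 40 nM.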

Compound 4, half-maximal inhibitory concentration: 2 nM
Compound 4: the middle estimate sits 6.0-fold (0.78 log units) above what was measured; measured number outside the range, below it.
By their numbers in this assay, from the lowest: compound 4; then compounds 2 and 3 (each within the scatter of the next); then compound 1.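

This place on the chain tolerates loss of the phenyl: in this assay, 4-methylthiophen-3-yl in its stead gives a 3.0-fold lower number from compound 2 to compound 4 (0.48 log units; beyond the scatter), a step beyond the scatter. Phenyl is therefore not required here, and 4-methylthiophen-3-yl is accepted on the core of compound 2. Nothing measured on these compounds accounts for the lower number.

Going by these compounds, whether the methyl or the thiophene ring carries the step stays open; a plain thiophene without the methyl would separate the two. Also open, on these data alone, is whether the step persists with the methoxy of compound 3 on the same core.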